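A few compounds are considered here, and "the series" means these few. Any claim that something is new, unique, unknown or untested is made for them only; others in the source may bear on it.

Measured in a functional assay on SEM cells (Homo sapiens) for cytotoxicity, with a stated time of 72 h; on this read-out higher numbers stand for an effect only at larger amounts of compound and lower numbers for an effect already at smaller amounts:
- Compound 1 `C=C[C@@](C)(/C=C/c1ccc(Nc2ccc(F)cc2)cc1)CCC=C(C)C`: > 36600 nM (a limit)
- Compound 2 `C=C[C@@](C)(/C=C/c1ccc(Nc2c(F)cc(F)cc2F)cc1)CCC=C(C)C`: > 36600 nM (a limit)
- Compound 3 `C=C[C@@](C)(/C=C/c1ccc(Nc2ccc(C(F)(F)F)cc2)cc1)CCC=C(C)C`: > 36600 nM (a limit)

Going by the values given here, compound 1 has no number of its own in this assay, only a limit, and the series so far offers nothing but (the limit of > 36600 nM in this assay, at which 3 of the 3 values shown sit). The unmeasured compound 4 `C=C[C@@](C)(/C=C/c1ccc(-c2ccc(F)cc2)cc1)CCC=C(C)C` differs from compound 1 by a single change: 4-fluorophenyl in place of (4-fluorophenyl)amino on an aromatic carbon. Here 4-fluorophenyl stands in place of (4-fluorophenyl)amino on an aromatic carbon, so the nitrogen leaves and the ring stays.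

Two measured steps start from compound 1, and both keep that nitrogen: a step that the two limits leave unreadable from compound 1 to compound 2, and a step that the two limits leave unreadable from compound 1 to compound 3. Among the compounds with values here, neither has a readable size, and no measured step removes the nitrogen. Compound 1 gives > 36600 nM, which is a limit, and this is the only footing for the expectation.

No step beyond the scatter is therefore expected, and the estimated step is a step that the limit leaves unreadable from compound 1 to compound 4. Compound 4 is expected at 40000 nM, with an estimated range from 15000 nM to 100000 nM, and it may well report only a limit in this assay.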

Compound 4, half-maximal effective concentration: > 36600 nM
Compound 4: a limit, no number; the forecaster's own chance of this, stated with the estimate: 75%; the middle value lies beyond the limit too.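

In this assay compound 4 gives > 36600 nM, which is a limit and not a number. Going by these compounds alone, compound 1 also has only a limit, so no step between compound 1 and compound 4 can be read. All the compounds shown end at the same point: the limit of > 36600 nM in this assay, at which 4 of the 4 values shown sit.

They leave open what value any of these compounds has in this assay, and whether replacing (4-fluorophenyl)amino with 4-fluorophenyl changes it.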